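Oxetan-3-yl in place of isopropyl on the ether oxygen

The source may report more compounds than this note shows. Statements on the series, on what has been measured and on what is new or still open speak of the compounds shown alone.

Among the compounds with values here, in a functional assay on HeLa cells (Homo sapiens) for antiproliferative activity, read by MTT assay, with a stated time of 48 h (on this read-out higher numbers stand for weaker inhibition and lower numbers for stronger inhibition), compound 1 `COc1cc(-c2nnc3c(OC)cc(-c4ccc5c(ccn5C)c4)cn23)cc(OC)c1OC` gives 15 nM and compound 2 `COc1cc(-c2nnc3c(OC(C)C)cc(-c4ccc5c(ccn5C)c4)cn23)cc(OC)c1OC` gives 503 nM, the higher of the two numbers so far. Compound 3 `COc1cc(-c2nnc3c(OC4COC4)cc(-c4ccc5c(ccn5C)c4)cn23)cc(OC)c1OC` carries oxetan-3-yl in place of isopropyl on an oxygen on an aromatic ring, oxetan-3-yl in place of isopropyl on an oxygen on an aromatic ring. Within the data shown here, one measured step bears on this place: a 34-fold higher number from compound 1 to compound 2 (1.53 log units; beyond the scatter), a large step with isopropyl in place of methyl. Among the measured compounds shown here, no oxetan-3-yl compound has been measured, so little recovery towards compound 1 is expected. The expected change is a 1.7-fold lower number from compound 2 to compound 3 (0.22 log units; within the scatter), which would stay within the scatter. Compound 3 is estimated at 300 nM, with an expected range of 60 nM to 1500 nM.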

Compound 3, half-maximal inhibitory concentration: 214 nM
Estimate against measurement, compound 3: 1.4-fold (0.15 log units) above, within the range that was stated.
By their numbers in this assay, from the lowest: compound 1; then compound 3; then compound 2.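

In this assay oxetan-3-yl on the oxygen gives a 2.4-fold lower number from compound 2 to compound 3 (0.37 log units; beyond the scatter) as a modest step, so the group with more heavy atoms and one hydrogen-bond acceptor does not raise the number over isopropyl. Methyl still leads, with a 14-fold higher number from compound 1 to compound 3 (1.15 log units; beyond the scatter) remaining as a large gap, so only part of the loss seen with isopropyl is regained. Nothing on hand accounts for this partial recovery. Open, as far as these compounds go, is whether an ethyl group, a 2-methoxyethyl chain or an amine-bearing chain on this oxygen would come closer to methyl.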